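Growing the Alkyl Amine on a Toll-like Receptor 8 Agonist

A few compounds are considered here, and "the series" means these few. Any claim that something is new, unique, unknown or untested is made for them only; others in the source may bear on it.

Compound 1 `CCCCCNc1oc2c(C)ncc(CO)c2c1Nc1cccc([N+](=O)[O-])c1` stimulates a functional assay on HEK293 cells for agonist activity at Toll-like receptor 8 (Homo sapiens), read by reporter gene assay (on this read-out lower numbers stand for an effect already at smaller amounts and higher numbers for an effect only at larger amounts of compound), with 850 nM. Compound 2 `Cc1ncc(CO)c2c(Nc3ccccn3)c(NC(C)C)oc12`, bearing an isopropylamino group, is recorded in this assay as "not active" (no number reported), so no number marks where it stands. Compound 3 `Cc1ncc(CO)c2c(Nc3ccccn3)c(NC(C)(C)CC(C)(C)C)oc12` starts from compound 2 and adds (neopentyl in place of hydrogen on a saturated chain carbon bound to a nitrogen on an aromatic ring and two saturated chain carbons). For the measured compounds named here, no measured pair shows this step, so its size is unknown; a gain in activity is plausible because compound 1, with its larger pentylamino chain, gives 850 nM. Compound 3 is therefore expected to reach about 1500 nM, within a range from 300 nM to 8000 nM.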

Compound 3, half-maximal effective concentration: "not active" (no number reported)
For compound 3 the study gives words and no number; there is nothing to compare the estimate with.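

In this assay, for the compounds shown here, compound 2 and compound 3 are both recorded as not active, so no step between them can be read, and no evidence on hand bears on this result. Going by these compounds alone, what stays open is how the alkyl amine alone affects activity, as compound 1, the only one with a number, differs from both in a second place.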